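Inverting both stereocentres of compound 2

The source may hold more compounds than are shown below. What is called first, only, known or untested is meant among the compounds shown, and "the series" means these compounds.

Among the measured compounds shown here, in an ADME assay on liver for metabolic stability, with Liver microsome (Rattus norvegicus) as the target, read by LC-MS, using microsomes, with a stated time of 5 h (on this read-out higher numbers stand for fast clearance and lower numbers for slow clearance), compound 2 (`O[C@]1(c2ccccn2)CC[C@@H](c2ccc(C(F)(F)F)cc2)C1`) gives 7670 mL/min/kg, the highest of the two numbers so far. Compound 1 (`O[C@@]1(c2ccccn2)CC[C@@H](c2ccc(C(F)(F)F)cc2)C1`) gives 2520 mL/min/kg, the nearest and only other value.

Compound 3 (`O[C@@]1(c2ccccn2)CC[C@H](c2ccc(C(F)(F)F)cc2)C1`) is the next to be read: the two compounds have the same atoms and bonds and differ only in configuration as drawn: 2 of 2 stereo elements differ (all stereocentres are inverted: mirror images); a stereocentre at a saturated ring carbon is drawn R in compound 2 and S in compound 3; a stereocentre at a saturated ring carbon is drawn R in compound 2 and S in compound 3. No group leaves or enters, and compound 3 is the mirror image of compound 2.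

For the measured compounds named here, one measured step bears on this. It is a 3.0-fold higher number from compound 1 to compound 2 (0.48 log units; beyond the scatter), a modest move beyond the scatter, and what defines it is the fact that compounds 1 and 2 differ only in the configuration as drawn. Going by the values given here, that step inverts a single stereocentre, so no measured step matches the full inversion, and its size carries over only loosely. Compound 2 sits at the top of the range with 7670 mL/min/kg, so a downward move seems more likely than a further rise, though a result near compound 2 remains possible.

The expected change is a modest fall in this assay, estimated as a 1.7-fold lower number from compound 2 to compound 3 (0.24 log units; within the scatter).

Compound 3 is estimated at 4400 mL/min/kg, with an expected range of 1700 mL/min/kg to 11000 mL/min/kg.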

Compound 3, clearance: 350 mL/min/kg
Estimate against measurement, compound 3: 13-fold (1.10 log units) above; the measured number lies below the stated range.
By their numbers in this assay, from the lowest: compound 3; then compound 1; then compound 2.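

In this assay, among the compounds shown here, configuration alone now spans a wide range of clearance within one set of atoms and bonds, with the mirror-image pair showing a 22-fold lower number from compound 2 to compound 3 (1.34 log units; beyond the scatter), a large change and the widest step so far: the fact that compounds 2 and 3 differ only in the configuration as drawn The single inversion from compound 1 to compound 3 is also beyond the scatter, at a 7.2-fold lower number from compound 1 to compound 3 (0.86 log units; beyond the scatter), so both stereocentres have now been seen to shift the number, each in a step that changes that centre alone: the fact that compounds 1 and 3 differ only in the configuration as drawn Compound 1 sits between the other two, with one inversion raising the number and the other lowering it, and compound 3 has the lowest clearance of the three, with its steps to both others beyond the scatter.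

These three compounds do not show what in the structure makes the number depend so strongly on configuration, nor which part of the molecule is involved. As far as these compounds go, whether the same order of configurations would hold with an amine or a carboxylic acid in place of the hydroxyl group, or a nitrile in place of the trifluoromethyl group, remains open.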